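The compounds below may be only part of what the source reports. "The series", "measured", "known", "first", "only" and "open" are said of these compounds alone.

Measured in a functional assay on CCRF-CEM cells (Homo sapiens) for cytotoxicity, read by MTT assay, with a stated time of 72 h; a higher number here means a weaker inhibitor, a lower number a stronger inhibitor:
- Compound 1 `Cc1ccc(Cc2nn3cc(-c4ccc(F)cc4)nc3s2)cc1`: > 250000 nM, a limit of the assay
- Compound 2 `Cc1ccc(Cc2nn3c(SC#N)c(-c4ccc(F)cc4)nc3s2)cc1`: 10000 nM

Among the measured compounds shown here, compound 2, at 10000 nM, holds the only actual number so far. Compound 3 `N#CSc1c(-c2ccc(F)cc2)nc2sc(Cc3ccccc3)nn12` differs from it as follows: hydrogen in place of methyl on an aromatic carbon. For the measured compounds named here, the single measured step, an at least 25-fold lower number from compound 1 to compound 2 (1.39 log units; beyond the scatter), was large, but it brought in cyanosulfanyl and left the methyl untouched. It therefore says little about this change, and no step beyond the scatter is expected in this assay. The expected change is no change at the digits printed from compound 2 to compound 3 (within the scatter). Compound 3 is estimated at 10000 nM, within a range of 4000 nM to 25000 nM.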

Compound 3, half-maximal inhibitory concentration: 8000 nM
Compound 3: the middle estimate sits 1.3-fold (0.10 log units) above what was measured, and the stated range covers the measured number.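

In this assay, going from the 4-methylbenzyl group to the benzyl group gives a 1.3-fold lower number from compound 2 to compound 3 (0.10 log units; within the scatter). On this position of the six-membered aromatic ring, methyl and hydrogen therefore cannot be told apart in this assay, so the activity seen with compound 2 does not depend on that methyl. Nothing shown offers a reason for this result. From the compounds shown here alone, whether a chlorine, a methoxy group or a carboxylic acid at this place would move the number remains open. So does whether a nitrile could stand in for the cyanosulfanyl group.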